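A few compounds are considered here, and "the series" means these few. Any claim that something is new, unique, unknown or untested is made for them only; others in the source may bear on it.

Measured so far in a functional assay on cells (Cancer cell lines, Homo sapiens) for cytotoxicity, with a stated time of 48 h; on this read-out lower numbers stand for stronger inhibition of growth and higher numbers for weaker inhibition of growth:
compound 1 `COc1cc2c(/C=C3/C(=O)Nc4ccc(O)cc43)c(Cl)n(Cc3cc(OC)c(OC)c(OC)c3)c2cc1C` gives 49000 nM
compound 2 `COc1cc2c(/C=C3/C(=O)Nc4cccc(Cl)c43)c(Cl)n(Cc3cc(OC)c(OC)c(OC)c3)c2cc1C` gives 10000 nM
compound 3 `COc1c(/C=C2/C(=O)Nc3ccccc32)c2ccccc2n1-c1ccccc1` gives 3240 nM

Compound 3 stands lowest of the three numbers in this assay, with compound 2 nearest and compound 1 furthest. The next compound, compound 4 `COc1ccc2c(c1)/C(=C\c1c(OC)n(-c3ccccc3)c3ccccc13)C(=O)N2`, differs from compound 3 by methoxy in place of hydrogen on an aromatic carbon. Within the data shown here, the one measured step, a 4.9-fold lower number from compound 1 to compound 2 (0.69 log units; beyond the scatter), concerns a different core and a different exchange, so it bears only loosely on this change; no measured pair shows methoxy against hydrogen at this place. The step in this assay is therefore expected to stay within the scatter, in either direction. Compound 4 is thus estimated at 3500 nM, with a range of 1200 nM to 10000 nM, which would mean an expected step of a 1.1-fold higher number from compound 3 to compound 4 (0.03 log units; within the scatter).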

Compound 4, concentration for total growth inhibition: 11000 nM
Estimate against measurement, compound 4: 3.1-fold (0.50 log units) below; measured number outside the range, above it.
By their numbers in this assay, from the lowest: compound 3; then compounds 2 and 4 (each within the scatter of the next); then compound 1.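

In this assay, methoxy in place of hydrogen on this aromatic carbon gives a 3.4-fold higher number from compound 3 to compound 4 (0.53 log units; beyond the scatter), so this position on the core of compound 3 does not tolerate every exchange without a change in growth inhibition. Among these compounds, this is the first measured exchange on that core, and it goes toward weaker inhibition. No measured evidence explains the step.

Going by these compounds, whether the rise is particular to methoxy stays open, and fluorine, an amine or a carboxylic acid on this carbon would test it. Also open, on these data alone, is whether methoxy has a like effect on other cores.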